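Swapping a sulfonamide for an amide on a weak lead

This account rests on a few compounds, and the source may have more. Where it says the series, first, only, none or still open, it means among the compounds named here.

Measured so far:
- compound 1 `O=S(=O)(NCCCNc1nccc(-c2c(-c3cccc(F)c3)nc3sccn23)n1)c1ccc(F)cc1`: > 20000 nM
- compound 2 `O=S(=O)(NCCNc1nccc(-c2c(-c3cccc(F)c3)nc3sccn23)n1)c1ccc(F)cc1`: 9450 nM

Both compounds were tested in a functional assay on SK-MEL-28 cells (Homo sapiens) for cytotoxicity, read by MTT assay; on this read-out higher numbers stand for weaker inhibition and lower numbers for stronger inhibition. For compound 1 the value > 20000 nM is a limit of the assay rather than a number. Compound 2 gives 9450 nM in this assay. Among the compounds with values here, the only step measured so far, an at least 2.1-fold lower number from compound 1 to compound 2 (0.32 log units; beyond the scatter), comes from shortening the chain between the two nitrogens. Compound 1 thus stands at the weak end of what is known, as the limit of > 20000 nM in this assay, at which 1 of the 2 values shown sits, shows.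

Compound 3 `O=C(NCCCNc1nccc(-c2c(-c3cccc(F)c3)nc3sccn23)n1)c1ccc(Cl)cc1` differs from compound 1 in another way: (4-chlorophenyl)carbonyl in place of (4-fluorophenyl)sulfonyl on an amine nitrogen. Within the data shown here, no measured step speaks to this kind of exchange; the step of an at least 2.1-fold lower number from compound 1 to compound 2 (0.32 log units; beyond the scatter) changes the chain and not the group on the amine nitrogen, so it gives no direction for this assay. With compound 1 sitting at the limit, compound 3 is expected to stay in the same weak region, with no step beyond the scatter, a number no higher from compound 1 to compound 3 (the limit leaves the size open). The estimate for compound 3 in this assay is therefore 20000 nM, within a range from 7000 nM to 60000 nM, and it may well again come back only as a limit.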

Compound 3, half-maximal inhibitory concentration: > 20000 nM
Compound 3 ended at the assay's limit (the forecaster's own chance of this, stated with the estimate: 55%); the middle value lies on the limit itself.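

Compound 3 shows that placing (4-chlorophenyl)carbonyl on the amine nitrogen, with the chain of compound 1 kept, does not bring a readable number in this assay: its result is again a limit of the assay and not a number, so the step from compound 1 to compound 3 cannot be read. What can be read is an at least 2.1-fold higher number from compound 2 to compound 3 (0.32 log units; beyond the scatter), although this step changes the chain and the group on the nitrogen together, so it cannot be assigned to either change alone. The exchange of (4-fluorophenyl)sulfonyl for (4-chlorophenyl)carbonyl has therefore not moved this chain away from the weak end of what is known, which remains: the limit of > 20000 nM in this assay, at which 2 of the 3 values shown sit.

As far as these compounds go, it remains open what (4-chlorophenyl)carbonyl would do on the shorter chain of compound 2, where a change in either direction could be read as a number, and whether the carbonyl or the chlorine counts more, as the two changed at once. Also open, from the compounds shown here alone, is how a free amine or a plain benzoyl group would behave on the same nitrogen.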